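Bromo in place of hydrogen on the shared core

The compounds below may be only part of what the source reports. "The series", "measured", "known", "first", "only" and "open" are said of these compounds alone.

For the measured compounds named here, in a physicochemical assay for solubility, at pH 6.8 (on this read-out higher numbers stand for higher solubility and lower numbers for lower solubility), compound 3 `Cc1c(COc2cccc(OCC3CCOCC3)c2)[nH]c2ccccc2c1=O` gives 5000 nM, the only exact number among the measured compounds. Compound 1 `Cc1c(COc2cccc(OCC3CCOCC3)c2)[nH]c2ccc(C(=O)O)cc2c1=O` reads >= 100000 nM, which is a limit. Compound 2 `Cc1c(COc2cccc(OCC3CCOCC3)c2)[nH]c2ccc(Cl)cc2c1=O` reads < 1000 nM, also a limit. Compound 4 `Cc1c(COc2cccc(OCC3CCOCC3)c2)[nH]c2ccc(Br)cc2c1=O` carries bromo in place of hydrogen on an aromatic carbon. The closest measured change puts chloro on that same carbon, and the step of an at least 5.0-fold higher number from compound 2 to compound 3 (0.69 log units; beyond the scatter) lies beyond the scatter. The carboxy step an at least 20-fold lower number from compound 1 to compound 3 (1.30 log units; beyond the scatter) bears on it less directly. Read in reverse, the chloro step points to a lower number in this assay, of modest size or more. The expected step is a 10-fold lower number from compound 3 to compound 4 (1.00 log units; beyond the scatter). For compound 4 the estimated value is 500 nM, with an expected range from 150 nM to 1500 nM.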

Compound 4, solubility: < 1000 nM
Compound 4: only a limit was reported; the forecaster's own chance of this, stated with the estimate: 65%; the middle value does not contradict the limit.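

Bromo in place of hydrogen on this aromatic carbon gives an at least 5.0-fold lower number from compound 3 to compound 4 (0.69 log units; beyond the scatter), the same direction as chloro there, whereas carboxy in compound 1 stands apart with an at least 100-fold lower number from compound 1 to compound 4 (2.00 log units; beyond the scatter). In this assay compound 4 gives < 1000 nM, which is a limit. Compound 2 and compound 4 share this limit, so the step between them cannot be read: the limit of < 1000 nM in this assay, at which 2 of the 4 values shown sit.

From the compounds shown here alone, how far the true values of compound 2 and compound 4 lie from that limit stays open. Also open, going by these compounds, is whether an amine or a methoxy group on this carbon would read closer to compound 3 or to compound 1.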